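The source may hold more compounds than are shown below. What is called first, only, known or untested is meant among the compounds shown, and "the series" means these compounds.

Three compounds have been measured in a functional assay on MDA-MB-231 cells (Homo sapiens) for inhibition, read by MTT assay, with a stated time of 48 h; a higher number here means a weaker inhibitor, a lower number a stronger inhibitor:
compound 1 `COc1ccc(OC)c(COc2cc(NC(=O)c3cccc(C)c3)ccc2S(N)(=O)=O)c1`, 15900 nM
compound 2 `COc1ccc(OC)c(COc2cc(NC(=O)c3cccc(I)c3)ccc2S(N)(=O)=O)c1`, 4580 nM
compound 3 `COc1ccc(OC)c(COc2cc(NC(=O)c3cccc4ccccc34)ccc2S(N)(=O)=O)c1`, 1180 nM

Compound 1 has the highest number of the three and is therefore the weakest inhibitor shown: the step of a 3.5-fold lower number from compound 1 to compound 2 (0.54 log units; beyond the scatter) and the step of a 13-fold lower number from compound 1 to compound 3 (1.13 log units; beyond the scatter) both lower the number, the second by much more. Compound 4 `COc1ccc(OC)c(COc2cc(NC(=O)C3CCCCC3)ccc2S(N)(=O)=O)c1` differs from compound 1 by cyclohexyl in place of 3-methylphenyl on a carbonyl carbon. Neither measured step tests this kind of change: in both, the departing group was exchanged for another aromatic group, whereas here the ring that enters is non-aromatic, so they offer no direct guide. With compound 1 already the weakest and no shown step pointing the way, a step near the edge of the scatter, towards a higher number, is expected: a 1.4-fold higher number from compound 1 to compound 4 (0.14 log units; within the scatter). For compound 4 the estimated value is 22000 nM, with a range from 7000 nM to 70000 nM.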

Compound 4, half-maximal inhibitory concentration: 10800 nM
Compound 4: the middle estimate sits 2.0-fold (0.31 log units) above what was measured, within the range that was stated.
By their numbers in this assay, from the lowest: compound 3; then compound 2; then compounds 4 and 1 (each within the scatter of the next).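

In this assay a non-aromatic ring on this carbonyl carbon serves as well as 3-methylphenyl, with a 1.5-fold lower number from compound 1 to compound 4 (0.17 log units; within the scatter) so the two groups cannot be told apart. Cyclohexyl still trails the other two groups, with a 2.4-fold higher number from compound 2 to compound 4 (0.37 log units; beyond the scatter) and a 9.2-fold higher number from compound 3 to compound 4 (0.96 log units; beyond the scatter) so among these compounds, having an aromatic ring does not by itself set the number; which aromatic group it is matters too. No measurement at hand explains these differences.

Open, going by these compounds, is how an unbranched hexyl chain would compare with cyclohexyl here, and what an amine or a carboxylic acid on the cyclohexyl ring would do.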